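The compounds below may be only part of what the source reports. "The series", "measured", "known", "first", "only" and "open" are said of these compounds alone.

Two compounds of this series have numbers. Compound 1 `O=C(COc1ccc2cc(/C=C3/SC(=O)NC3=O)ccc2c1)Nc1ccc(Br)cc1F` gives 1900 nM in an assay on isolated protein for inhibition of histone deacetylase 4 (Homo sapiens), with a stated time of 1 h; a lower number here means a stronger inhibitor, a higher number a weaker inhibitor. Compound 2 `Cc1cc(NC(=O)COc2ccc3cc(/C=C4/SC(=O)NC4=O)ccc3c2)no1` gives 1700 nM in this assay; the step of a 1.1-fold lower number from compound 1 to compound 2 (0.05 log units; within the scatter) shows that exchanging the group on the amide-type nitrogen left the inhibition unchanged beyond the scatter. Compound 2 therefore stands together with compound 1, the two values being indistinguishable, and neither can be called the stronger inhibitor.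

Compound 3 `O=C(COc1ccc2cc(/C=C3/SC(=O)NC3=O)ccc2c1)Nc1ccc(Cl)c(Cl)c1` is the next compound to be measured. Its difference from compound 2 is 3,4-dichlorophenyl in place of 5-methyl-1,2-oxazol-3-yl on an amide-type nitrogen. Within the data shown here, the only measured step that bears on this position is the one from compound 1 to compound 2, where a 4-bromo-2-fluorophenyl and a 5-methyl-1,2-oxazol-3-yl gave the same number within the scatter. The present change again replaces the group on the amide-type nitrogen with a halogenated benzene ring, so no movement beyond the scatter is expected in this assay, in either direction. Compound 3 is therefore estimated at 1800 nM with a range from 900 nM to 3600 nM, which corresponds to an expected step of a 1.1-fold higher number from compound 2 to compound 3 (0.02 log units; within the scatter).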

Compound 3, half-maximal inhibitory concentration: 5500 nM
For compound 3 the middle estimate is 3.1-fold (0.49 log units) below the measured one; the measured number lies above the stated range.
By their numbers in this assay, from the lowest: compounds 2 and 1 (each within the scatter of the next); then compound 3.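

In this assay the group on the amide-type nitrogen does affect the number: with a 3.2-fold higher number from compound 2 to compound 3 (0.51 log units; beyond the scatter) and a 2.9-fold higher number from compound 1 to compound 3 (0.46 log units; beyond the scatter), both modest but beyond the scatter, compound 3 is the weakest inhibitor of the three. A halogenated benzene ring does not by itself set the value, since the 4-bromo-2-fluorophenyl of compound 1 stands level with the 5-methyl-1,2-oxazol-3-yl of compound 2, while the 3,4-dichlorophenyl of compound 3 stands apart from both. No measurement at hand explains this difference between the two halogenated rings.

The three compounds leave open whether the higher number follows from the two chlorines together or from one of them, a question that an unsubstituted phenyl or a 4-chlorophenyl on the same nitrogen would address. They also leave open whether this position can give a clearly stronger inhibitor than compound 2, at 1700 nM, for instance with a phenyl ring carrying a carboxylic acid or a dimethylamino group.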